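Hydrazone-type side chains and Vero cytotoxicity in the series

The compounds below may be only part of what the source reports. "The series", "measured", "known", "first", "only" and "open" are said of these compounds alone.

Compound 1 `CO/N=C(\C)CN1CCN(c2c(F)cc3c(=O)c(C(=O)O)cn(C4CC4)c3c2OC)CC1C` gives 49.6 ug/mL in an ADME assay on Vero cells (Chlorocebus sabaeus) for cytotoxicity, read by MTT assay, with a stated time of 72 h (on this read-out higher numbers stand for lower toxicity in this test and lower numbers for higher toxicity in this test), and stands second highest of the three numbers recorded so far. Compound 3 `COc1c(N2CCN(CC/C(C)=N/O)C(C)C2)c(F)cc2c(=O)c(C(=O)O)cn(C3CC3)c12` gives 44.2 ug/mL in this assay; the step of a 1.1-fold lower number from compound 1 to compound 3 (0.05 log units; within the scatter) shows that the longer chain alone moves nothing. Compound 2 `COc1c(N2CCN(C/C(C)=N/NC(C)=O)C(C)C2)c(F)cc2c(=O)c(C(=O)O)cn(C3CC3)c12` gives 707 ug/mL in this assay; the step of a 14-fold higher number from compound 1 to compound 2 (1.15 log units; beyond the scatter) and the step of a 16-fold lower number from compound 2 to compound 3 (1.20 log units; beyond the scatter) are the only large movements among the measured compounds, and both go with a change of the group attached to the double-bonded nitrogen.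

Compound 4 `COc1c(N2CCN(CC/C(C)=N/NC(N)=O)C(C)C2)c(F)cc2c(=O)c(C(=O)O)cn(C3CC3)c12` has not been measured. Change from compound 1: a group of 8 heavy atoms (4 carbon, 3 nitrogen, 1 oxygen; no ring) in place of a group of 5 heavy atoms (3 carbon, 1 nitrogen, 1 oxygen; no ring), on a saturated chain carbon bound to an amine nitrogen in a ring. Going by the values given here, the group that enters resembles the one in compound 2 rather than the methoxy on a double-bonded nitrogen of compound 1, and it sits on a chain of the length seen in compound 3. The step of a 14-fold higher number from compound 1 to compound 2 (1.15 log units; beyond the scatter) therefore bears on the case most directly, while a 1.1-fold lower number from compound 1 to compound 3 (0.05 log units; within the scatter) indicates the chain length adds little. A large upward step, beyond the scatter, is expected. Compound 4 is estimated at 400 ug/mL with a range of 100 ug/mL to 1500 ug/mL. The expected step is an 8.1-fold higher number from compound 1 to compound 4 (0.91 log units; beyond the scatter).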

Compound 4, half-maximal cytotoxic concentration: 31.3 ug/mL
For compound 4 the middle estimate is 13-fold (1.11 log units) above the measured one; measured number outside the range, below it.
By their numbers in this assay, from the lowest: compounds 4, 3 and 1 (each within the scatter of the next); then compound 2.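

In this assay the ureido group on the double-bonded nitrogen does not bring the high number seen with the acetamido group: a 23-fold lower number from compound 2 to compound 4 (1.35 log units; beyond the scatter), whereas a 1.6-fold lower number from compound 1 to compound 4 (0.20 log units; within the scatter) and a 1.4-fold lower number from compound 3 to compound 4 (0.15 log units; within the scatter). Going by these compounds alone, both of these smaller steps are within the scatter, so a carbonyl-bearing group on the double-bonded nitrogen is not enough by itself to set a compound apart from compounds 1 and 3, and compound 2 now stands alone as the only high value. The group that changes from compound 2 to compound 4 differs both in its chain and in what sits on the double-bonded nitrogen, so this step does not separate the two changes, and nothing measured here explains the gap to compound 2.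

Still open, on these data alone, is whether the acetamido group keeps its high number on the chain of compound 3, and whether the ureido group reaches that number on the chain of compound 1. Also open, as far as these compounds go, is how a primary amine or a carboxylic acid carried on the end of this side chain would read in this assay.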